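Working notes: methyl in place of fluoro, compound 4

A few compounds are considered here, and "the series" means these few. Any claim that something is new, unique, unknown or untested is made for them only; others in the source may bear on it.

Measured in a functional assay on A549 cells (Homo sapiens) for antiproliferative activity, read by MTT assay, with a stated time of 72 h; on this read-out higher numbers stand for weaker inhibition and lower numbers for stronger inhibition
- compound 1 `C=CC(=O)Nc1cccc(Oc2nc(Nc3ccn(C)n3)nc3c2CSCC3)c1` gives 18600 nM
- compound 2 `C/C=C/C(=O)Nc1cccc(Oc2nc(Nc3ccn(C)n3)nc3c2CSCC3)c1` gives > 50000 nM (a limit)
- compound 3 `C=C(F)C(=O)Nc1cccc(Oc2nc(Nc3ccn(C)n3)nc3c2CSCC3)c1` gives > 50000 nM (a limit)

Compound 3 stands at the limit of > 50000 nM in this assay, at which 2 of the 3 values shown sit, and so offers no number to start from. Compound 4 `C=C(C)C(=O)Nc1cccc(Oc2nc(Nc3ccn(C)n3)nc3c2CSCC3)c1` carries methyl in place of fluoro on a double-bonded chain carbon bound to a carbonyl carbon. Both measured changes to the vinyl of compound 1 gave weaker inhibition, an at least 2.6-fold higher number from compound 1 to compound 2 (0.42 log units; beyond the scatter) and an at least 2.6-fold higher number from compound 1 to compound 3 (0.42 log units; beyond the scatter), and the second is the closer precedent, since it changes the same carbon. Compound 4 is therefore expected to stay close to compound 3 in this assay, with no step beyond the scatter and quite possibly only a limit again. The expected size is an at least 1.1-fold lower number from compound 3 to compound 4 (0.04 log units; that floor lies within the scatter) and its direction cannot be read from a limit. The estimate for compound 4 is 45000 nM (expected range 22000 nM to 80000 nM).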

Compound 4, half-maximal inhibitory concentration: 46900 nM
Compound 4: the middle estimate sits 1.0-fold (0.02 log units) below what was measured; the measured number falls inside the stated range.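

Methyl on the double-bonded chain carbon bound to a carbonyl carbon gives a readable number, so the cost of replacing hydrogen at this carbon can now be sized (a 2.5-fold higher number from compound 1 to compound 4 (0.40 log units; beyond the scatter)). Against the two compounds that rest on a limit, only floors can be read (an at least 1.0-fold lower number from compound 3 to compound 4 (0.02 log units; that floor lies within the scatter); an at least 1.0-fold lower number from compound 2 to compound 4 (0.02 log units; that floor lies within the scatter)), and methyl cannot be ordered against fluoro or prop-1-en-1-yl. Those comparisons end at a limit: the limit of > 50000 nM in this assay, at which 2 of the 4 values shown sit.

Open, on these data alone, is whether an aminomethyl group or a longer chain such as ethyl on the same carbon would return to the level of compound 1 or pass it.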